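Two Limits and a Swap at One Aromatic Carbon

The source may hold more compounds than are shown below. What is called first, only, known or untested is meant among the compounds shown, and "the series" means these compounds.

Measured in an ADME assay on Raji cells (Homo sapiens) for cytotoxicity, with a stated time of 72 h; on this read-out lower numbers stand for an effect already at smaller amounts and higher numbers for an effect only at larger amounts of compound:
- compound 1 `Cc1cc(NC(=O)Nc2ccc(C(C)(C)C)cc2)c2ccccc2n1`: > 25000 nM (a limit)
- compound 2 `Cc1cc(NC(=O)Nc2ccc(O)cc2)c2ccccc2n1`: > 25000 nM (a limit)

Compound 2 stands at > 25000 nM, which is a limit of the assay and not a number. The picture so far is the limit of > 25000 nM in this assay, at which 2 of the 2 values shown sit. Compound 3 `Cc1cc(NC(=O)Nc2ccc(SC(F)(F)F)cc2)c2ccccc2n1` carries (trifluoromethyl)sulfanyl in place of hydroxy on an aromatic carbon. Within the data shown here, the only measured step is a step that the two limits leave unreadable from compound 1 to compound 2. It offers no size or direction to carry over, so no change beyond the scatter is expected in this assay. The expected outcome is a number no higher from compound 2 to compound 3 (the limit leaves the size open). Compound 3 is estimated at 25000 nM, with an expected range from 10000 nM to 50000 nM.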

Compound 3, half-maximal effective concentration: 10000 nM
The estimate for compound 3 lay 2.5-fold (0.40 log units) above the measured number, and the stated range covers the measured number.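

In this assay, the group on this aromatic carbon can change the read-out: (trifluoromethyl)sulfanyl in place of hydroxy gives an at least 2.5-fold lower number from compound 2 to compound 3 (0.39 log units; beyond the scatter), and in place of tert-butyl it gives an at least 2.5-fold lower number from compound 1 to compound 3 (0.39 log units; beyond the scatter). Among these compounds, compound 3 is the only compound here with a number rather than a limit. The other two values offer no number to compare: the limit of > 25000 nM in this assay, at which 2 of the 3 values shown sit.

On these data alone, whether the sulfur or the fluorine atoms matter more stays open. So does whether an amine or a carboxylic acid on this carbon would also give a number rather than a limit.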